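Swapping the ring on the chain carbon of compound 2

This account rests on a few compounds, and the source may have more. Where it says the series, first, only, none or still open, it means among the compounds named here.

Measured so far in an ADME assay on microsomes from liver (Homo sapiens) for metabolic stability; a higher number here means that the compound lasts longer, a lower number that the compound disappears faster:
Compound 1 `CC(C)(/C=C1\OC(=O)NC1=O)c1ccc(-c2ccc3cccc(F)c3c2)[nH]c1=O` gives 1.89 h.
Compound 2 `CC(C)C(c1ccc(-c2ccc3cccc(F)c3c2)[nH]c1=O)C1SC(=O)NC1=O` gives 1.87 h.
Compound 3 `O=C1NC(=O)/C(=C/C2(c3ccc(-c4ccc5cccc(F)c5c4)[nH]c3=O)CCCC2)O1` reaches only the limit of this assay, reported as > 3 h.

Compound 2 and compound 1 give numbers that sit within the usual scatter of each other, so neither can be called the longer-lived. The third value is a limit, not a number, as the one entry at the limit of > 3 h in this assay, at which 1 of the 3 values shown sits, shows. Compound 4 `CC(C)C(/C=C1\SC(=O)NC1=O)c1ccc(-c2ccc3cccc(F)c3c2)[nH]c1=O` is not yet measured. It differs from compound 2 in one place: a group of 8 heavy atoms (4 carbon, 1 nitrogen, 2 oxygen, 1 sulfur; one five-membered non-aromatic ring with 2 hetero atoms) in place of a group of 7 heavy atoms (3 carbon, 1 nitrogen, 2 oxygen, 1 sulfur; one five-membered non-aromatic ring with 2 hetero atoms), on a saturated chain carbon bound to an aromatic carbon and a saturated chain carbon. Going by the values given here, no measured pair shows this kind of change, so the expectation rests on the neighbours. Compound 1 carries a related ring joined through a double bond and gives 1.89 h, which is within the scatter of compound 2. The step from compound 2 to compound 4 is therefore expected to be small, a 1.0-fold higher number from compound 2 to compound 4 (0.01 log units; within the scatter), none beyond the scatter. Compound 4 is estimated at 1.9 h, within a range from 1 h to 3.5 h.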

Compound 4, half-life: > 3 h
Compound 4 ended at the assay's limit (the forecaster's own chance of this, stated with the estimate: 15%); middle value at least 1.5-fold (0.19 log units) from the limit.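

In this assay, going by these compounds alone, this is the first pair that isolates a change on the saturated chain carbon, replacing the 2,4-dioxo-1,3-thiazolidin-5-yl group with a ring of the same type joined through a double bond: an at least 1.6-fold higher number from compound 2 to compound 4 (0.20 log units; that floor lies within the scatter). The value of compound 4, > 3 h, is a limit and not a number, so the step is only a floor. The pair shows that the new group does not shorten the half-life, although the floor alone does not establish a change beyond the usual scatter, and compound 4 joins the entries at the ceiling of the read-out: the limit of > 3 h in this assay, at which 2 of the 4 values shown sit.

From the compounds shown here alone, how far compound 4 lies past the limit remains open. It is also unknown how a carboxylic acid or an amine would behave in place of the ring on this chain carbon.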